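Methoxycarbonyl to ketoester chain on the amine nitrogen

This account rests on a few compounds, and the source may have more. Where it says the series, first, only, none or still open, it means among the compounds named here.

Compound 3 `COC(=O)NC1=CS(=O)(=O)O[C@@]12[C@@H](CO[Si](C)(C)C(C)(C)C)O[C@@H](n1cc(C)c(=O)n(C)c1=O)[C@@H]2O[Si](C)(C)C(C)(C)C` carries a methoxycarbonyl on an amine nitrogen; in a functional assay on HEL cells (Homo sapiens) for cytotoxicity, read by microscopy (on this read-out higher numbers stand for lower toxicity in this test and lower numbers for higher toxicity in this test), compound 3 gives only a limit, >= 50000 nM. Compound 1 `Cc1cn([C@@H]2O[C@H](CO[Si](C)(C)C(C)(C)C)[C@@]3(OS(=O)(=O)C=C3NCC(=O)C(=O)N3CCC3)[C@H]2O[Si](C)(C)C(C)(C)C)c(=O)n(C)c1=O` gives 65000 nM. Compound 2 `COC(=O)CNC1=CS(=O)(=O)O[C@@]12[C@@H](CO[Si](C)(C)C(C)(C)C)O[C@@H](n1cc(C)c(=O)n(C)c1=O)[C@@H]2O[Si](C)(C)C(C)(C)C` likewise gives a limit, >= 400000 nM. Compound 4 `COC(=O)C(=O)CNC1=CS(=O)(=O)O[C@@]12[C@@H](CO[Si](C)(C)C(C)(C)C)O[C@@H](n1cc(C)c(=O)n(C)c1=O)[C@@H]2O[Si](C)(C)C(C)(C)C` differs from compound 3 by ((methoxycarbonyl)carbonyl)methyl in place of methoxycarbonyl on an amine nitrogen. The two steps that reach compound 3, a step that the limit leaves unreadable from compound 1 to compound 3 and a step that the two limits leave unreadable from compound 2 to compound 3, stay unreadable. The step of an at least 6.1-fold higher number from compound 1 to compound 2 (0.78 log units; beyond the scatter) exchanges the same end group that sets compound 4 apart from compound 1, so compound 4 is expected to land near compound 1 or higher, possibly again at a limit. Compound 4 is therefore estimated at 200000 nM, between 50000 nM and 600000 nM, an expected step that the limit leaves unreadable from compound 3 to compound 4 that the limit of compound 3 leaves uncertain.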

Compound 4, minimum cytotoxic concentration: > 400000 nM
Compound 4: only a limit was reported; the forecaster's own chance of this, stated with the estimate: 50%; middle value at least 2.0-fold (0.30 log units) from the limit.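

With the chain on the amine nitrogen otherwise unchanged, methoxy in place of azetidin-1-yl on a carbonyl carbon gives an at least 6.1-fold higher number from compound 1 to compound 4 (0.78 log units; beyond the scatter) in this assay, so the lower number of compound 1 goes with the azetidin-1-yl end group and not with the two-carbonyl chain as such. The value of compound 4 is only a limit: the limit of > 400000 nM in this assay, at which 1 of the 4 values shown sits. The steps linking compound 4 with compound 2 and compound 3 cannot be read.

Open, as far as these compounds go, is whether a pyrrolidin-1-yl or dimethylamino end group on that carbonyl carbon would also lower the number. Also open, from the compounds shown here alone, is how compound 2, compound 3 and compound 4 truly rank.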